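Methoxy Added to the Free Amine Core

The source may hold more compounds than are shown below. What is called first, only, known or untested is meant among the compounds shown, and "the series" means these compounds.

Compound 1 `C=C(Br)C(=O)Nc1ccc(/C=C/C(=O)c2ccccc2)cc1` and compound 2 `C=C(Br)C(=O)Nc1ccc(/C=C/C(=O)c2ccc(OC)cc2)cc1` differ by methoxy in place of hydrogen on an aromatic carbon. In a functional assay on FM3A cells (Mus musculus) for antiproliferative activity, with a stated time of 48 h (a lower number here means a stronger inhibitor, a higher number a weaker inhibitor), compound 1 gives 3900 nM, while compound 2 gives 1200 nM, a step of a 3.3-fold lower number from compound 1 to compound 2 (0.51 log units; beyond the scatter). Compound 3 `Nc1ccc(/C=C/C(=O)c2ccccc2)cc1` has a different core, the difference being (hydrogen in place of (1-bromoethenyl)carbonyl on a nitrogen on an aromatic ring), and in this assay compound 3 gives 146000 nM, so that a 37-fold higher number from compound 1 to compound 3 (1.57 log units; beyond the scatter). Compound 4 `COc1cccc(C(=O)/C=C/c2ccc(N)cc2)c1` has not been measured; it differs from compound 3 by methoxy in place of hydrogen on an aromatic carbon. This is the same kind of change as that from compound 1 to compound 2, though the place differs: there the methoxy stands para to a large group, here meta to a large group. Given that the earlier step was a 3.3-fold lower number from compound 1 to compound 2 (0.51 log units; beyond the scatter) at a different place, compound 4 is expected to gain somewhat less, a step of a 1.6-fold lower number from compound 3 to compound 4 (0.21 log units; within the scatter). Compound 4 is therefore estimated at 90000 nM, between 40000 nM and 250000 nM.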

Compound 4, half-maximal inhibitory concentration: 43000 nM
For compound 4 the middle estimate is 2.1-fold (0.32 log units) above the measured one; low and high end bracket the measured number.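

In this assay, methoxy meta to a large group on the free amine core gives a 3.4-fold lower number from compound 3 to compound 4 (0.53 log units; beyond the scatter), and this step agrees with the one seen on the other core, where the methoxy stands at a different place: the same change on two cores in this assay, a 3.3-fold lower number (0.51 log units; beyond the scatter) from compound 1 to compound 2 and a 3.4-fold lower number (0.53 log units; beyond the scatter) from compound 3 to compound 4, 1.0-fold (0.02 log units) apart, within the scatter of two such steps

So in this series the lowering of the number carried over from one core to the other, even with the place changed. It rests on a single pair of cores, however, and does not show what either place would give on the other core, since core and place change together between the two steps.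

Going by these compounds, whether methoxy at the other place on each core would give a like step stays open. So does whether an ethoxy or a hydroxy group would carry across these cores as methoxy does.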